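The compounds below may be only part of what the source reports. "The series", "measured", "known", "first", "only" and "open" are said of these compounds alone.

Measured so far:
compound 1, `COCc1ccccc1C1Cc2nccn2C1` — > 10000 nM
compound 2, `c1ccc(C2CCc3nc[nH]c3C2)cc1` — > 10000 nM; > 10000 nM; > 10000 nM (3 entries)

In a functional assay on CHO cells for agonist activity at Alpha-1B adrenergic receptor (Homo sapiens), read by FLIPR and calcium flux (a lower number here means that less compound is needed, a higher number that more compound is needed for the effect), compound 1 gives > 10000 nM, which is a limit of the assay rather than a number. Compound 2 gives > 10000 nM; > 10000 nM; > 10000 nM (3 entries) in each of its three entries, again only a limit. Within the data shown here, compound 1 therefore stands at the limit of > 10000 nM in this assay, at which 1 of the 2 values shown sits, and no step between two measured compounds with single numbers is available to set a scale for change.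

Compound 3, `Clc1ccccc1C1Cc2nccn2C1`, differs from compound 1 by chloro in place of methoxymethyl on an aromatic carbon. With both measured compounds sitting at the limit, the step from compound 1 to compound 3 is expected to amount to none beyond the scatter, as a step that the limit leaves unreadable from compound 1 to compound 3 expresses; compound 3 is expected to remain at or near the limit. For compound 3 in this assay the estimate is 20000 nM, with a range from 3000 nM to 100000 nM.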

Compound 3, half-maximal effective concentration: 1100 nM
Compound 3: middle estimate off by 18-fold (1.26 log units), on the high side; the whole stated range lies above it.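

In this assay, among these compounds, chloro in place of methoxymethyl on the aromatic carbon ortho to a group of 8 heavy atoms brings an at least 9.0-fold lower number from compound 1 to compound 3 (0.95 log units; beyond the scatter), the first step that can be read at all. The earlier compounds shown here gave only limits and could not show that a change at this one place on the shared core is enough to bring a single number within reach of the assay. The step is a minimum rather than a measured size, because compound 1 stands at a limit: the limit of > 10000 nM in this assay, at which 1 of the 3 values shown sits.

The compounds shown leave open whether the step belongs to the arrival of chloro or to the departure of methoxymethyl, as this one pair cannot separate the two. Going by these compounds, how a methyl group, a bromine atom or an amine on the same carbon would compare also remains open.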